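Carboxyphenyl ether series: aryl swap on the ether oxygen

The source may hold more compounds than are shown below. What is called first, only, known or untested is meant among the compounds shown, and "the series" means these compounds.

Measured so far, in an assay on HEK293 cells for positive allosteric modulation of metabotropic glutamate receptor 3 (Rattus norvegicus), read by thallium flux, with a stated time of 2.5 min; on this read-out lower numbers stand for an effect already at smaller amounts and higher numbers for an effect only at larger amounts of compound:
compound 1 `Cc1c(OCCCCOc2ccc(C(=O)O)cc2F)ccc(C(=O)CC(C)C)c1O`: 1420 nM
compound 2 `Cc1c(OCCCCOc2ccc(C(=O)O)cc2Cl)ccc(C(=O)CC(C)C)c1O`: 1140 nM

Compound 2 holds the lowest of the two numbers, but its nearest neighbour, compound 1, sits a 1.2-fold lower number from compound 1 to compound 2 (0.10 log units; within the scatter), so the two are not separated by the measurement. For the measured compounds named here, the one measured step, chloro for fluoro on the aromatic carbon, therefore says only that this halogen exchange leaves the read-out essentially unchanged.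

Compound 3 `Cc1ccc(C(=O)O)cc1OCCCCOc1ccc(C(=O)CC(C)C)c(O)c1C` differs from compound 2 by 5-carboxy-2-methylphenyl in place of 4-carboxy-2-chlorophenyl on an oxygen on a saturated carbon. Going by the values given here, no measured pair covers a change of this kind: both the carboxy group and the second substituent on that ring are shifted in name, which goes beyond the halogen exchange seen in compound 1 and compound 2. The expectation is accordingly loose, leaning towards a modest increase in the number, as a 1.9-fold higher number from compound 2 to compound 3 (0.29 log units; within the scatter), with a wide range. Compound 3 is estimated at 2200 nM, between 700 nM and 7000 nM.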

Compound 3, half-maximal effective concentration: > 10000 nM
Compound 3: a limit, no number; the forecaster's own chance of this, stated with the estimate: 10%; at least 4.5-fold (0.65 log units) between middle value and limit.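

Compound 3 stands at a limit of this assay, not at a number: the limit of > 10000 nM in this assay, at which 1 of the 3 values shown sits.

The aryl swap on an oxygen on a saturated carbon gives an at least 8.7-fold higher number from compound 2 to compound 3 (0.94 log units; beyond the scatter) and an at least 7.0-fold higher number from compound 1 to compound 3 (0.84 log units; beyond the scatter); unlike the halogen exchange, these steps lie beyond the scatter, so the read-out does respond to a change at this place. Both steps are lower bounds, and their full size cannot be read from a limit.

The swap puts methyl in place of the halogen and changes the placing of the carboxy group in a single step, and the compounds shown do not separate these two changes. They also leave open how an amide or a nitrile in place of the carboxy group would read.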